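Solubility of compound 4 after swapping an azetidine for a tolyl ring

This account rests on a few compounds, and the source may have more. Where it says the series, first, only, none or still open, it means among the compounds named here.

Measured so far:
compound 1, `OCC1CCN(c2nccnc2OC2CN(c3nc4ccccc4s3)C2)CC1`, 31000 nM
compound 2, `OCC1CCN(c2cccnc2OC2CN(c3ccc4ccccc4n3)C2)CC1`, 189000 nM
compound 3, `OC1CN(c2nccnc2OC2CN(c3ccc4ccccc4n3)C2)C1`, 41000 nM

These three compounds were characterised in a physicochemical assay for solubility, in phosphate buffer, at pH 7.4; on this read-out lower numbers stand for lower solubility and higher numbers for higher solubility. Compound 3 stands second highest of the three numbers. Its nearest neighbour is compound 1, whose value lies within the scatter of that of compound 3, so no order between the two can be read. Compound 2 gives a higher number than compound 3, and that gap lies beyond the scatter. No pair of these compounds differs in one place only, so no single step between measured compounds can be drawn from them.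

Compound 4, `Cc1ccc(-c2nccnc2OC2CN(c3ccc4ccccc4n3)C2)cc1`, has not been measured in this assay. Compared with compound 3, the change is 4-methylphenyl in place of 3-hydroxyazetidin-1-yl on an aromatic carbon. The group that leaves carries 1 hydrogen-bond donor and 2 hydrogen-bond acceptors; the group that enters carries none of either.

Among the measured compounds shown here, no measured step speaks to this change, so the expectation rests on the structural difference alone. Compound 4 is expected to give a lower number than compound 3, with an estimated step of an 8.2-fold lower number from compound 3 to compound 4 (0.91 log units; beyond the scatter), beyond the scatter. For compound 4 the estimate in this assay is 5000 nM, in a range from 1000 nM to 25000 nM.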

Compound 4, solubility: < 1000 nM
Compound 4: no number, only a limit; the forecaster's own chance of this, stated with the estimate: 10%; middle value at least 5.0-fold (0.69 log units) away from the limit.
By their numbers in this assay, from the lowest: compounds 1 and 3 (each within the scatter of the next); then compound 2. At a limit, below all of these: compound 4.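

In this assay, among the compounds shown here, the exchange of 3-hydroxyazetidin-1-yl for 4-methylphenyl gives the first step between compounds that differ in one place: an at least 41-fold lower number from compound 3 to compound 4 (1.61 log units; beyond the scatter), a large step, on an aromatic carbon next to the ring nitrogen, which shows that the read-out responds strongly to the group at this position. Compound 4 gives < 1000 nM, which is a limit of the assay and not a number. The step therefore has a known minimum but no measured end: the limit of < 1000 nM in this assay, at which 1 of the 4 values shown sits.

What the compounds shown leave open is which part of the exchange carries the step, whether the loss of the hydroxyl with its hydrogen-bond donor, the loss of the four-membered non-aromatic ring, or the entry of a six-managed aromatic ring of carbon only, because this single exchange alters them all at once.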